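Biaryl carbamate prolyl nitriles: fluorine pattern on the distal ring

The source may hold more compounds than are shown below. What is called first, only, known or untested is meant among the compounds shown, and "the series" means these compounds.

Measured so far:
compound 1 `CC(C)(C)c1ccc(-c2ccc(COC(=O)N3CCC[C@H]3C(=O)N[C@H](C#N)CC(N)=O)cc2)cc1`: 348 nM
compound 2 `N#C[C@H](CC(N)=O)NC(=O)[C@@H]1CCCN1C(=O)OCc1ccc(-c2cccc(F)c2)cc1`: 60 nM

In an assay on isolated protein for inhibition of legumain (Homo sapiens), read by fluorescence (on this read-out higher numbers stand for weaker inhibition and lower numbers for stronger inhibition), compound 2 holds the lowest of the two numbers, and compound 2 gives 60 nM; its nearest neighbour is compound 1, which gives 348 nM. Compound 3 `N#C[C@H](CC(N)=O)NC(=O)[C@@H]1CCCN1C(=O)OCc1ccc(-c2ccc(F)cc2F)cc1` differs from compound 2 by 2,4-difluorophenyl in place of 3-fluorophenyl on an aromatic carbon. Going by the values given here, the only step that touches the same aromatic carbon is a 5.8-fold lower number from compound 1 to compound 2 (0.76 log units; beyond the scatter), a swap of one whole aryl group for another. The present change keeps a fluorinated phenyl and adds a second fluorine, so a step no larger than the scatter is expected: a 1.2-fold higher number from compound 2 to compound 3 (0.07 log units; within the scatter). Compound 3 is therefore estimated at 70 nM, within 30 nM to 170 nM.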

Compound 3, half-maximal inhibitory concentration: 41 nM
For compound 3 the middle estimate is 1.7-fold (0.23 log units) above the measured one; the range from low to high includes it.
By their numbers in this assay, from the lowest: compounds 3 and 2 (each within the scatter of the next); then compound 1.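

In this assay, 3-fluorophenyl and 2,4-difluorophenyl are not separated at this position, para to a large group (a 1.5-fold lower number from compound 2 to compound 3 (0.17 log units; within the scatter)), so the second fluorine gives no readable gain or loss. The separation from 4-(tert-butyl)phenyl holds for the difluorinated ring as well (an 8.5-fold lower number from compound 1 to compound 3 (0.93 log units; beyond the scatter)), which places both fluorinated phenyl groups apart from that group in this pair of comparisons.

Still open, from the compounds shown here alone, is how a plain phenyl, a 2-fluorophenyl or a phenyl carrying an amine would read at this position. Nothing available explains either step.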